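This account rests on a few compounds, and the source may have more. Where it says the series, first, only, none or still open, it means among the compounds named here.

Measured in an ADME assay on L02 cells (Homo sapiens) for cytotoxicity, read by MTT assay, with a stated time of 24 h (on this read-out higher numbers stand for weaker inhibition and lower numbers for stronger inhibition), so far:
Compound 1 `CC(=O)Nc1ccc(S(=O)(=O)N2C/C(=C\c3ccc(C#N)cc3)C(=O)/C(=C/c3ccc(C#N)cc3)C2)cc1` gives 14000 nM
Compound 2 `CC(=O)Nc1ccc(S(=O)(=O)N2C/C(=C\c3ccc(C#N)cc3)C(=O)/C(=C/c3ccccc3F)C2)cc1` gives 14400 nM

Compound 2 stands level with compound 1, as their two values lie within the scatter of each other. Compound 3 `COc1cc(/C=C2\CN(S(=O)(=O)c3ccc(NC(C)=O)cc3)C/C(=C\c3ccc(C#N)cc3)C2=O)cc(OC)c1OC` departs from compound 2 by 3,4,5-trimethoxyphenyl in place of 2-fluorophenyl on a double-bonded chain carbon bound to a double-bonded ring carbon in words, 3,4,5-trimethoxyphenyl in place of 2-fluorophenyl on a double-bonded chain carbon bound to a double-bonded ring carbon. Within the data shown here, only one measured step bears on this place: a 1.0-fold higher number from compound 1 to compound 2 (0.01 log units; within the scatter) when 2-fluorophenyl took the place of 4-cyanophenyl, a step within the scatter. Among the measured compounds shown here, no measured compound carries 3,4,5-trimethoxyphenyl, so this single step is a thin guide. Even so, no change beyond the scatter is expected in this assay for this swap. The expected step is a 1.1-fold lower number from compound 2 to compound 3 (0.04 log units; within the scatter) by this estimate. For compound 3 the estimated value is 13000 nM with an expected range of 5500 nM to 30000 nM on measurement.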

Compound 3, half-maximal inhibitory concentration: 13600 nM
For compound 3 the middle estimate is 1.0-fold (0.02 log units) below the measured one, within the range that was stated.
By their numbers in this assay, from the lowest: compounds 3, 1 and 2 (each within the scatter of the next).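

In this assay, the place on a double-bonded chain carbon bound to a double-bonded ring carbon now also holds 3,4,5-trimethoxyphenyl, with a 1.1-fold lower number from compound 2 to compound 3 (0.02 log units; within the scatter) and a 1.0-fold lower number from compound 1 to compound 3 (0.01 log units; within the scatter). A group of 12 heavy atoms with 3 hydrogen-bond acceptors thus leaves the number within the scatter, which the earlier pair, with 2-fluorophenyl and 4-cyanophenyl, could not show. Nothing at hand accounts for this.

The compounds shown leave open whether the number stays level when this place carries something other than a substituted phenyl, such as an amine or a longer alkyl chain, or a phenyl bearing a carboxylic acid. They also leave open whether it stays level when the 4-cyanophenyl common to all three compounds is replaced.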